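A few compounds are considered here, and "the series" means these few. Any claim that something is new, unique, unknown or untested is made for them only; others in the source may bear on it.

Working notes on the series. Within the data shown here, in a functional assay (ileum) for antagonist activity, with Cavia porcellus as the target (on this read-out higher numbers stand for weaker binding and lower numbers for tighter binding), compound 1 (`N#Cc1nc2ccccc2nc1N1CCNCC1`) gives 1580 nM and compound 2 (`CCN1CCN(c2nc3ccccc3nc2C#N)CC1`) gives 63.1 nM, so compound 2 holds the lower of the two numbers so far. Among the measured compounds shown here, the only measured step, a 25-fold lower number from compound 1 to compound 2 (1.40 log units; beyond the scatter), lies beyond the scatter.

The next member is compound 3 (`CCCN1CCN(c2nc3ccccc3nc2C#N)CC1`). The change is methyl in place of hydrogen on a saturated chain carbon, two bonds along the chain from an amine nitrogen in a ring, which turns ethyl into propyl.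

For the measured compounds named here, the one measured step bears on this only indirectly. It put ethyl in place of hydrogen on the amine nitrogen, whereas here an existing chain grows. Nothing yet shows how chain length beyond ethyl plays out, so the large step to compound 2 at 63.1 nM should not be extrapolated. A small change is expected, most likely within the scatter, with a slight lean towards a higher number.

The estimate amounts to an expected 1.3-fold higher number from compound 2 to compound 3 (0.10 log units; within the scatter). For compound 3 the expected value is 80 nM, with an estimated range of 25 nM to 250 nM.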

Compound 3, dissociation constant: 1000 nM
Estimate against measurement, compound 3: 13-fold (1.10 log units) below; measured number outside the range, above it.
By their numbers in this assay, from the lowest: compound 2; then compounds 3 and 1 (each within the scatter of the next).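

Growing ethyl to propyl on this chain is no minor edit in this assay: the one added methyl gives a 16-fold higher number from compound 2 to compound 3 (1.20 log units; beyond the scatter) and, across compound 1, compound 2 and compound 3, the read-out does not move in one direction as the group on the amine nitrogen in a ring grows. Propyl in place of hydrogen on that nitrogen gives a 1.6-fold lower number from compound 1 to compound 3 (0.20 log units; within the scatter) and so leaves compound 3 and compound 1 within the scatter of each other, while compound 2 alone stands beyond the scatter of both, which makes the large step seen earlier specific to ethyl among these three compounds rather than a general result of substituting that nitrogen. The data at hand offer nothing that explains why one added methyl on the chain has so large an effect.

Methyl, butyl and isopropyl on the amine nitrogen in a ring remain open, so it cannot yet be said whether the low number of compound 2 belongs to ethyl alone or extends to other small groups. Also open is whether a cyclopropyl group, close in size to the groups shown, would read like ethyl or like propyl.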